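The compounds below may be only part of what the source reports. "The series", "measured", "known", "first", "only" and "open" are said of these compounds alone.

Measured so far in an ADME assay on HEp-2 cells (Homo sapiens) for cytotoxicity; a lower number here means that less compound is tolerated, a higher number that more compound is tolerated:
- Compound 1 `Cc1ccnc(C)c1NC(=O)[C@@H]1CCCN1S(=O)(=O)c1cccc2cccnc12`: > 50000 nM
- Compound 2 `Cc1ccc(C(F)(F)F)cc1NC(=O)[C@@H]1CCCN1S(=O)(=O)c1cccc2cccnc12`: 4800 nM

Compound 1 reads > 50000 nM, which is a limit of the assay and not a number. Within the data shown here, that leaves compound 2, at 4800 nM, as the only exact reading available. The two compounds differ in more than one place, so their gap cannot be pinned on any single group.

The next compound, compound 3 `Cc1ccc(C(C)C)cc1NC(=O)[C@@H]1CCCN1S(=O)(=O)c1cccc2cccnc12`, keeps the rest of compound 2 and changes one group. It has isopropyl in place of trifluoromethyl on an aromatic carbon, para to a methyl group and meta to a large group: isopropyl in place of trifluoromethyl on an aromatic carbon.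

Among the measured compounds shown here, no measured pair shows what a single change does here. With compound 2 at 4800 nM as the only anchor, this swap is expected to produce no shift in this assay beyond the usual scatter. The expected step of a 1.1-fold higher number from compound 2 to compound 3 (0.06 log units; within the scatter) is therefore small and has no firm direction. For compound 3 the estimated value is 5500 nM, with an expected range of 2000 nM to 15000 nM.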

Compound 3, half-maximal cytotoxic concentration: 9700 nM
Compound 3: middle estimate off by 1.8-fold (0.25 log units), on the low side; low and high end bracket the measured number.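

Swapping trifluoromethyl for isopropyl on the aromatic carbon para to a methyl group gives a 2.0-fold higher number from compound 2 to compound 3 (0.31 log units; beyond the scatter) in this assay, the first change of a single small group in this set, and it shows that this position can move the reading, though only modestly, towards more compound being tolerated. Replacing the whole 2,4-dimethylpyridin-3-yl on the amide-type nitrogen with 5-isopropyl-2-methylphenyl gives an at least 5.1-fold lower number from compound 1 to compound 3 (0.71 log units; beyond the scatter), so the isopropyl compound still sits well short of the reading of the compound that carries the other ring group. The true size of that second step stays unknown, as compound 1 gives a limit of the assay and not a number: the limit of > 50000 nM in this assay, at which 1 of the 3 values shown sits.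

As far as these compounds go, two groups on one carbon cannot establish a trend, so it remains open how a methoxy group, a nitrile or an amine at this position would read. From the compounds shown here alone, it is also open whether a simple methyl or a larger tert-butyl there would continue the step seen with isopropyl or reverse it.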